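The source may report more compounds than this note shows. Statements on the series, on what has been measured and on what is new or still open speak of the compounds shown alone.

Of the compounds shown here, three sharing one core have been measured in a functional assay on OVCAR-3 cells (Homo sapiens) for inhibition, read by MTT assay, with a stated time of 24 h; on this read-out lower numbers stand for stronger inhibition and higher numbers for weaker inhibition. Compound 1 `CC1(C)[C@H]2CC[C@]1(C)N(Cc1cn(-c3ccccc3Br)nn1)C(=O)C2` gives 140 nM, compound 2 `CC1(C)[C@H]2CC[C@]1(C)N(Cc1cn(-c3cccc(C#N)c3)nn1)C(=O)C2` gives 230 nM, and compound 3 `CC1(C)[C@H]2CC[C@]1(C)N(Cc1cn(-c3ccccc3Cl)nn1)C(=O)C2` gives 40 nM. Compound 2 carries the largest number of the three, yet the step of a 1.6-fold higher number from compound 1 to compound 2 (0.22 log units; within the scatter) stays within the scatter, while a 5.8-fold lower number from compound 2 to compound 3 (0.76 log units; beyond the scatter) and a 3.5-fold lower number from compound 1 to compound 3 (0.54 log units; beyond the scatter) lie beyond it. Compound 4 `CC1(C)[C@H]2CC[C@]1(C)N(Cc1cn(-c3ccc(Cl)cc3)nn1)C(=O)C2` has not been measured; it differs from compound 2 by 4-chlorophenyl in place of 3-cyanophenyl on an aromatic nitrogen. The nearest guide is the step of a 5.8-fold lower number from compound 2 to compound 3 (0.76 log units; beyond the scatter), where a chlorophenyl also replaced the 3-cyanophenyl, although at another point of the ring. A lower number is therefore expected for compound 4, estimated as a 2.9-fold lower number from compound 2 to compound 4 (0.46 log units; beyond the scatter), giving 80 nM with a range from 30 nM to 250 nM.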

Compound 4, half-maximal inhibitory concentration: 160 nM
Beside the measured number, compound 4's estimate is 2.0-fold (0.30 log units) below it; the range from low to high includes it.
By their numbers in this assay, from the lowest: compound 3; then compounds 1, 4 and 2 (each within the scatter of the next).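

In this assay, the 4-chlorophenyl group in place of the 2-chlorophenyl group gives a 4.0-fold higher number from compound 3 to compound 4 (0.60 log units; beyond the scatter), so the low number of compound 3 does not extend to every chlorophenyl group at this aromatic nitrogen. The 4-chlorophenyl group cannot be separated from the 3-cyanophenyl group, with a 1.4-fold lower number from compound 2 to compound 4 (0.16 log units; within the scatter), or from the 2-bromophenyl group, with a 1.1-fold higher number from compound 1 to compound 4 (0.06 log units; within the scatter), as both steps stay within the scatter. Nothing available accounts for the difference between the two chlorophenyl groups. On these data alone, it remains open whether a methoxy group or an amine in place of the chloro of the 2-chlorophenyl group would hold the level of compound 3.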